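This account rests on a few compounds, and the source may have more. Where it says the series, first, only, none or still open, it means among the compounds named here.

Working notes on the series. All four compounds share one core; only the aryl group of the amide is varied. In an assay on HEK293 cells for binding affinity to Urotensin-2 receptor (Homo sapiens), read by radioligand binding (a lower number here means a stronger inhibitor, a higher number a weaker inhibitor), compound 1 `Cc1cc(C(=O)N[C@H]2CCN(Cc3ccc(OCCCN(C)C)cc3)C2)ccc1Cl` gives 631 nM. Compound 2 `Cc1ccc(C(=O)N[C@H]2CCN(Cc3ccc(OCCCN(C)C)cc3)C2)cc1C` reaches only the limit < 10000 nM in this assay, a limit and not a number. Compound 3 `CN(C)CCCOc1ccc(CN2CC[C@H](NC(=O)c3ccc(-c4ccccc4)cc3)C2)cc1` also stands at the limit < 10000 nM in this assay, so its position is known only as a limit. Among the compounds with values here, the single step between directly comparable compounds, a step that the limit leaves unreadable from compound 1 to compound 2, cannot be sized because the limit of < 10000 nM in this assay, at which 2 of the 3 values shown sit, holds one of its two ends.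

Compound 4 `CN(C)CCCOc1ccc(CN2CC[C@H](NC(=O)c3ccccc3)C2)cc1` differs from compound 3 by hydrogen in place of phenyl on an aromatic carbon. Within the data shown here, no measured step touches this phenyl group; the step from compound 1 to compound 2 concerns a different position and is itself unreadable, so it gives no size to carry over. Among the measured compounds shown here, compound 1, which carries a small substituted aryl amide, is the only compound with a numerical value, and compound 4 returns to a small aryl amide of that kind. The step expected for compound 4 is a step that the limit leaves unreadable from compound 3 to compound 4, its direction uncertain since compound 3 is known only as a limit. Compound 4 is expected at 3000 nM, with a range from 500 nM to 10000 nM.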

Compound 4, inhibition constant: 2510 nM
Beside the measured number, compound 4's estimate is 1.2-fold (0.08 log units) above it, and the stated range covers the measured number.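

With phenyl on the carbonyl carbon, the series gains a second number in this assay, and the change from 4-chloro-3-methylphenyl to phenyl can now be sized as a 4.0-fold higher number from compound 1 to compound 4 (0.60 log units; beyond the scatter). Within the data shown here, this is the first readable step, and although it lies beyond the scatter it is modest, so compound 4 keeps a measurable value with neither the chloro nor the methyl group of compound 1 on the aryl ring. The steps that link compound 4 to compound 2 and to compound 3 cannot be read, because each has a limit at one end, so the loss of the outer phenyl and the removal of the two methyl groups remain unsized: the limit of < 10000 nM in this assay, at which 2 of the 4 values shown sit.

Among these compounds, the one readable step removes the chloro and methyl groups together, which leaves open how much of it belongs to each, and a phenyl amide bearing a single chloro or a single methyl group would separate the two. From the compounds shown here alone, how a methoxy group, a nitrile or a carboxylic acid on that aromatic carbon would read in this assay also stays open, as does any change to the dimethylamino chain of the shared core.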